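This account rests on a few compounds, and the source may have more. Where it says the series, first, only, none or still open, it means among the compounds named here.

Of the compounds shown here, three of one shared core have been measured in an assay on HEK293 cells for displacement of a labelled ligand from prostaglandin D2 receptor 2 (Homo sapiens); on this read-out higher numbers stand for weaker inhibition and lower numbers for stronger inhibition. Compound 1 `O=C(O)Cn1c(SCc2ccc(Cl)cc2)nc2ccccc21` gives 160 nM. Compound 2 `COc1ccc(CSc2nc3ccccc3n2CC(=O)O)cc1` gives 210 nM, and compound 3 `Cc1ccc(CSc2nc3ccccc3n2CC(=O)O)cc1` gives 220 nM. The number of compound 3 is the highest of the three, but its gaps to compound 2 and to compound 1 are both within the scatter, so nothing separates these three compounds.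

Compound 4 `COC(=O)c1ccc(CSc2nc3ccccc3n2CC(=O)O)cc1` carries methoxycarbonyl in place of methyl on an aromatic carbon. The steps already taken at this same position are a 1.3-fold higher number from compound 1 to compound 2 (0.12 log units; within the scatter), a 1.4-fold higher number from compound 1 to compound 3 (0.14 log units; within the scatter) and a 1.0-fold higher number from compound 2 to compound 3 (0.02 log units; within the scatter). Each of them changed the group on that carbon, and none moved this assay beyond the scatter. Among the measured compounds shown here, no measured step introduces a methoxycarbonyl group or any group of its kind, so the data give no direct anchor for it.

Given that the three measured changes at this position all stayed within the scatter, the step from compound 3 to compound 4 is expected to be a 1.1-fold higher number from compound 3 to compound 4 (0.06 log units; within the scatter). Compound 4 is therefore estimated at 250 nM in this assay, with a range from 100 nM to 700 nM to allow for the untested nature of the new group.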

Compound 4, half-maximal inhibitory concentration: 10600 nM
Beside the measured number, compound 4's estimate is 42-fold (1.63 log units) below it, and the stated range ends below it.
By their numbers in this assay, from the lowest: compounds 1, 2 and 3 (each within the scatter of the next); then compound 4.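

In this assay this aromatic carbon, para to a large group, proves far from indifferent to what it carries: chloro, methoxy and methyl stayed within the scatter of one another, yet methoxycarbonyl brings large steps from all three (a 48-fold higher number from compound 3 to compound 4 (1.68 log units; beyond the scatter); a 50-fold higher number from compound 2 to compound 4 (1.70 log units; beyond the scatter); a 66-fold higher number from compound 1 to compound 4 (1.82 log units; beyond the scatter)). The earlier compounds therefore showed tolerance only among these three groups, and that tolerance does not extend to methoxycarbonyl, which has four heavy atoms, two hydrogen-bond acceptors and a double bond where methyl has one heavy atom and no acceptor. Nothing available here explains why this one change weakens inhibition so sharply.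

The compounds shown leave open whether the loss belongs to methoxycarbonyl alone or extends to other carbonyl-bearing groups on this carbon, such as an acetyl group, an amide or a free carboxylic acid. They also leave open whether a chain with no carbonyl, such as methoxymethyl or a longer alkyl chain, would stay with compounds 1, 2 and 3 or fall away like compound 4.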